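From methyl to benzyl on selenium: a short extrapolation

The source may report more compounds than this note shows. Statements on the series, on what has been measured and on what is new or still open speak of the compounds shown alone.

Compound 1 `CS/C(=N\C(=O)c1sccc1Cl)NC(=O)c1sccc1Cl` gives 57400 nM in a functional assay on PC-3 cells (Homo sapiens) for cytotoxicity, read by MTT assay, with a stated time of 72 h; on this read-out lower numbers stand for stronger inhibition of growth and higher numbers for weaker inhibition of growth.
Compound 2 `C[Se]/C(=N\C(=O)c1cccs1)NC(=O)c1cccs1` gives 63000 nM in this assay.
Compound 3 `O=C(/N=C(/NC(=O)c1cc(-c2ccccc2)nc2ccccc12)[Se]Cc1ccccc1)c1cc(-c2ccccc2)nc2ccccc12` gives 97100 nM in this assay.

Compound 2 stands second highest of the three numbers. Its nearest neighbour is compound 1, whose number lies within the scatter of its own, and its furthest is compound 3, also within the scatter. The three measured compounds therefore cannot be told apart in this assay.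

Compound 4 `O=C(/N=C(/NC(=O)c1cccs1)[Se]Cc1ccccc1)c1cccs1` differs from compound 2 by phenyl in place of hydrogen on a saturated chain carbon bound to a selenium atom. Among the measured compounds shown here, no pair of measured compounds shows this change in isolation. Compound 3, however, already carries the benzyl on selenium alongside a different acyl part, and its number in this assay sits within the scatter of compound 2. On that basis the expected step, a 1.0-fold higher number from compound 2 to compound 4 (0.01 log units; within the scatter), is none beyond the scatter. Compound 4 is estimated at 65000 nM in this assay, with a range from 30000 nM to 140000 nM.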

Compound 4, concentration for total growth inhibition: > 100000 nM
Compound 4 was reported as a limit; the forecaster's own chance of this, stated with the estimate: 10%; middle value at least 1.5-fold (0.18 log units) from the limit.
By their numbers in this assay, from the lowest: compounds 1, 2 and 3 (each within the scatter of the next). At a limit, above all of these: compound 4.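

Phenyl in place of hydrogen on a saturated chain carbon bound to a selenium atom, the change of methyl to benzyl, can now be read in isolation, with everything else in compound 2 held fixed. In this assay this change gives an at least 1.5-fold higher number from compound 2 to compound 4 (0.20 log units; that floor lies within the scatter). The result for compound 4 is a limit of the assay and not a number: the limit of > 100000 nM in this assay, at which 1 of the 4 values shown sits. The pair therefore shows no gain in growth inhibition from benzyl at this position, but the floor of the step does not establish a loss beyond the scatter.

The compounds shown leave open how far the step actually reaches past that floor. They also leave open how a longer chain such as ethyl, or an amine, would read on this same carbon in this assay.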